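Bromo to benzyloxy on the pendant aryl of the shared core

This account rests on a few compounds, and the source may have more. Where it says the series, first, only, none or still open, it means among the compounds named here.

The series shares one core, seen in compound 1 `Cc1cc(O)c(C(=O)/C=C/c2ccccc2)c(-c2ccccc2)c1C(=O)/C=C/c1ccccc1`, compound 2 `Cc1cc(O)c(C(=O)/C=C/c2ccccc2)c(-c2ccc(Br)cc2)c1C(=O)/C=C/c1ccccc1`, compound 3 `Cc1cc(O)c(C(=O)/C=C/c2ccc(OCc3ccccc3)cc2)c(-c2ccc(Br)cc2)c1C(=O)/C=C/c1ccc(OCc2ccccc2)cc1` and compound 4 `Cc1cc(O)c(C(=O)/C=C/c2ccccc2)c(-c2ccc(OCc3ccccc3)cc2)c1C(=O)/C=C/c1ccccc1`. In an ADME assay on HEK293 cells (Homo sapiens) for cytotoxicity, read by MTT assay, with a stated time of 24 h (on this read-out higher numbers stand for weaker inhibition and lower numbers for stronger inhibition), compound 1 is reported as "not active" (no number reported), with no number given. In this assay compound 2 gives 30000 nM, the highest of the two numbers recorded, and compound 3 gives 25000 nM; the two values lie within the scatter of each other, so no order between them is read. Compound 4 differs from compound 2 in one place: benzyloxy in place of bromo on an aromatic carbon. Among the measured compounds shown here, no measured pair shows this change, so the step from compound 2 to compound 4 cannot be read from the recorded numbers; compound 3, which carries benzyloxy elsewhere, sits within the scatter of compound 2, and nothing here points to a direction. The expectation is therefore a step of a 1.2-fold higher number from compound 2 to compound 4 (0.07 log units; within the scatter), none beyond the scatter. Compound 4 is thus estimated at 35000 nM in this assay, within a range from 14000 nM to 90000 nM.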

Compound 4, half-maximal inhibitory concentration: "not active" (no number reported)
For compound 4 the study gives words and no number; there is nothing to compare the estimate with.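

No new step can be read: in this assay compound 4 gives "not active" (no number reported), so benzyloxy in place of bromo cannot be sized against compound 2 at 30000 nM. No measured evidence bears on this result. The compounds shown leave open whether this change moves the read-out at all.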